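Methyl for piperidin-4-yl on an aromatic nitrogen, two cores

This account rests on a few compounds, and the source may have more. Where it says the series, first, only, none or still open, it means among the compounds named here.

Measured so far:
compound 1, `CC(Nc1ncnc2ncc(-c3cnn(C4CCNCC4)c3)cc12)c1c(Cl)ccc(F)c1Cl`, 17700 nM
compound 2, `CC(Nc1ncnc2ncc(-c3cnn(C)c3)cc12)c1c(Cl)ccc(F)c1Cl`, > 100000 nM
compound 3, `c1cnc2ccc(Nc3ncnc4ccc(-c5cnn(C6CCNCC6)c5)cc34)cc2c1`, 2660 nM

In a functional assay on SK-BR-3 cells (Homo sapiens) for antiproliferative activity, read by MTT assay, with a stated time of 72 h (on this read-out lower numbers stand for stronger inhibition and higher numbers for weaker inhibition), compound 1 gives 17700 nM. For compound 2 the read-out is a limit, > 100000 nM, not a number. The step is an at least 5.6-fold higher number from compound 1 to compound 2 (0.75 log units; beyond the scatter), the change being (methyl in place of piperidin-4-yl on an aromatic nitrogen). Its size is bounded by the limit of > 100000 nM in this assay, at which 1 of the 3 values shown sits, so the true step may be larger than stated.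

Compound 3 gives 2660 nM in this assay, the lowest number of the two measured values. The difference between the core of compound 3 and the core of compound 1 is not broken down here.

Compound 4, `Cn1cc(-c2ccc3ncnc(Nc4ccc5ncccc5c4)c3c2)cn1`, carries the same change on the core of compound 3: methyl in place of piperidin-4-yl on an aromatic nitrogen. The two places are identical in description, so this is the same change as that from compound 1 to compound 2. Among the compounds with values here, a step of similar size is expected, a 7.5-fold higher number from compound 3 to compound 4 (0.88 log units; beyond the scatter), resting on an at least 5.6-fold higher number from compound 1 to compound 2 (0.75 log units; beyond the scatter) as the only precedent. Compound 4 is therefore estimated at 20000 nM in this assay, with a likely span of 7000 nM to 80000 nM.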

Compound 4, half-maximal inhibitory concentration: 64 nM
The estimate for compound 4 lay 310-fold (2.49 log units) above the measured number; the whole stated range lies above it.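

In this assay the same change runs in opposite directions on the two cores, with a 42-fold lower number from compound 3 to compound 4 (1.62 log units; beyond the scatter) set against the earlier step, so in this series a step seen on one core does not carry over to the other: the same change on two cores in this assay, an at least 5.6-fold higher number (0.75 log units; beyond the scatter) from compound 1 to compound 2 and a 42-fold lower number (1.62 log units; beyond the scatter) from compound 3 to compound 4, at least 230-fold (2.37 log units) apart, beyond the scatter of two such steps. Going by these compounds, the earlier step rests on compound 2, whose read-out is a limit and not a number, so its true size stays open: the limit of > 100000 nM in this assay, at which 1 of the 4 values shown sits. The two pairs show that the outcome of this change depends on the core that carries it, but they do not show what causes the reversal, and they give no rule for a third core.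

On these data alone, it remains open which part of the difference between the two cores sets the direction of the step. Also open, as far as these compounds go, is how an ethyl group, a short chain ending in an amine or one ending in a carboxylic acid on the same aromatic nitrogen would read on each core.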